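Cyclopropyl on the amide nitrogen of two fluorinated cores

The compounds below may be only part of what the source reports. "The series", "measured", "known", "first", "only" and "open" are said of these compounds alone.

Measured so far in a functional assay on the whole organism with Mus musculus as the target, in the rotarod test; a lower number here means that less compound is needed, a higher number that more compound is needed for the effect:
- compound 1 `O=C(/C=C1\CCc2cc(F)ccc21)NC1CC1`: 193 mg/kg
- compound 2 `NC(=O)/C=C1\CCc2cc(F)ccc21`: a limit of this assay, > 100 mg/kg
- compound 3 `NC(=O)/C=C1\CCc2ccc(F)cc21`: 90 mg/kg

Compound 3 gives the lowest of the two numbers; compound 1 gives a higher number, and that gap lies beyond the scatter. Compound 2 and compound 3 are built from the same atoms joined differently, and the difference between the two cores is not broken down here.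

Compound 1 is made from compound 2 by one change, (cyclopropyl in place of hydrogen on an amide-type nitrogen). The size of that step, a step that the limit leaves unreadable from compound 2 to compound 1, cannot be read because of the limit of > 100 mg/kg in this assay, at which 1 of the 3 values shown sits.

Compound 4 `O=C(/C=C1\CCc2ccc(F)cc21)NC1CC1` carries the same change on the core of compound 3: cyclopropyl in place of hydrogen on an amide-type nitrogen. The place of the change is described in the same words for both pairs, so it is the same change, only made on a different core.

With the earlier step unreadable, the expectation for compound 4 rests on a single observation: compound 1 gives 193 mg/kg. For compound 2, the parent of compound 1, only a limit of this assay is reported. On that basis the step from compound 3 to compound 4 is expected to be a 1.8-fold higher number from compound 3 to compound 4 (0.25 log units; within the scatter), toward a higher number. Compound 4 is therefore estimated at 160 mg/kg, with a range from 60 mg/kg to 400 mg/kg.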

Compound 4, dose for half-maximal effect: 62 mg/kg
The estimate for compound 4 lay 2.6-fold (0.41 log units) above the measured number, and the stated range covers the measured number.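

In this assay the step on the core of compound 3 is a 1.5-fold lower number from compound 3 to compound 4 (0.16 log units; within the scatter) and so cannot be told apart from the ordinary spread of repeated measurements. On this core, then, a cyclopropyl on the amide-type nitrogen gives a result that this assay does not separate from that of the plain amide, but this single pair does not show that the change acts alike on both cores. A comparison of the two cores would need a second readable step, and the one on the other core cannot be read because compound 2 is reported only as a limit of the assay: the limit of > 100 mg/kg in this assay, at which 1 of the 4 values shown sits.

The compounds shown leave open whether any other group on this nitrogen would give a step beyond the scatter, for example a methyl, an isopropyl, a cyclobutyl or a longer chain such as n-butyl. They also leave open how the cyclopropyl step would look on a core that carries chlorine in place of the fluorine, or on the core of compound 2 if its parent amide gave a readable number.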